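The compounds below may be only part of what the source reports. "The series", "measured", "known", "first", "only" and "open" are said of these compounds alone.

Two members of the series have so far been taken through an ADME assay on L02 cells (Homo sapiens) for cytotoxicity, read by MTT assay, with a stated time of 48 h; a lower number here means a stronger inhibitor, a higher number a weaker inhibitor. Compound 2 `Cc1ccc2[nH]c(=O)c(-c3nc4cc(Br)ccc4[nH]3)cc2c1` reports only a limit in this assay, > 100000 nM, not a number. Compound 1 `COc1ccc2[nH]c(=O)c(-c3nc4cc(F)ccc4[nH]3)cc2c1` likewise reports only a limit in this assay, > 100000 nM. Everything measured so far therefore falls at one point: the limit of > 100000 nM in this assay, at which 2 of the 2 values shown sit. Compound 3 `COc1ccc2[nH]c(=O)c(-c3nc4cc(Br)ccc4[nH]3)cc2c1` is the methoxy counterpart of compound 2; the change is methoxy in place of methyl on an aromatic carbon. Within the data shown here, no measured pair isolates this change, and compound 1 already carries the methoxy group without leaving the limit. With both values shown sitting at the limit, no step beyond the scatter is expected in either direction in this assay. Compound 3 is expected to report a limit as well, with an estimate of 100000 nM spanning 50000 nM to 300000 nM. The expected step of a number no higher from compound 2 to compound 3 (the limit leaves the size open) is none beyond the scatter.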

Compound 3, half-maximal inhibitory concentration: > 100000 nM
Compound 3 ended at the assay's limit; the forecaster's own chance of this, stated with the estimate: 85%; the middle value sits exactly at the limit.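

Among these compounds, compound 3 joins compound 1 and compound 2 at the same limit, so no step among the three can be read in this assay: the limit of > 100000 nM in this assay, at which 3 of the 3 values shown sit. The compounds shown leave open how far each lies past that limit, and whether methoxy against methyl or bromo against fluoro makes any difference.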